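Ethyl to isopropyl on compound 3

The source may report more compounds than this note shows. Statements on the series, on what has been measured and on what is new or still open speak of the compounds shown alone.

In a functional assay on ileum (Cavia porcellus) for antagonist activity (a higher number here means a weaker inhibitor, a lower number a stronger inhibitor), compound 3 `CCc1ccccc1OCC(O)COc1ccc2c(O)c([N+](=O)[O-])c(=O)oc2c1` gives 2700 nM and holds the highest of the two numbers, while compound 1 `CCCc1c(OCCCOc2ccccc2)ccc2c(O)c([N+](=O)[O-])c(=O)oc12` at 540 nM lies lower, beyond the scatter. Compound 2 `O=c1oc2cc(OCCCOc3ccc(-c4ccccc4)cc3)ccc2c(O)c1[N+](=O)[O-]` returns > 20000 nM as its reading, which is a limit and not a number.

Compound 4 `CC(C)c1ccccc1OCC(O)COc1ccc2c(O)c([N+](=O)[O-])c(=O)oc2c1` departs from compound 3 in one place: methyl in place of hydrogen on a saturated chain carbon bound to an aromatic carbon and a saturated chain carbon with methyl in place of hydrogen on a saturated chain carbon bound to an aromatic carbon and a saturated chain carbon, so ethyl becomes isopropyl. Among the compounds with values here, no measured pair shows this change, so in this assay no step beyond the scatter is expected. The estimated shift is a 1.2-fold lower number from compound 3 to compound 4 (0.09 log units; within the scatter) as the expected step. For compound 4 the expected value is 2200 nM with 700 nM to 7000 nM as the estimated range.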

Compound 4, half-maximal inhibitory concentration: 160 nM
The estimate for compound 4 lay 14-fold (1.14 log units) above the measured number; the whole stated range lies above it.
By their numbers in this assay, from the lowest: compound 4; then compound 1; then compound 3. At a limit, above all of these: compound 2.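

Turning 2-ethylphenoxy into 2-isopropylphenoxy adds one methyl and gives a 17-fold lower number from compound 3 to compound 4 (1.23 log units; beyond the scatter) in this assay. Within the data shown here, this is the first pair in the set that differs in one place, and it shows that this saturated chain carbon bound to an aromatic carbon responds strongly to a very small addition. Nothing among the data shown accounts for the size of this step.

On these data alone, whether a tert-butyl group or a propyl chain at this place would lower the number further remains open. So does whether a methoxy group there would keep the gain.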